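Amide nitrogen substituent and cytotoxicity in the methylquinoline ethers

The source may report more compounds than this note shows. Statements on the series, on what has been measured and on what is new or still open speak of the compounds shown alone.

Compound 1 `COc1cccc(NC(=O)COc2cc(C)nc3ccc(OC)cc23)c1` carries a 3-methoxyphenyl group on the amide-type nitrogen; in an ADME assay on HepG2 cells (Homo sapiens) for cytotoxicity, read by trypan blue exclusion, with a stated time of 48 h, in the presence of a further agent that is not named here (on this read-out higher numbers stand for lower toxicity in this test and lower numbers for higher toxicity in this test), compound 1 gives 24700 nM. Compound 2 `COCCNC(=O)COc1cc(C)nc2ccc(OC)cc12` has 2-methoxyethyl in its place. In this assay compound 2 reaches only a limit of the test, reported as > 164000 nM. The one measured step, an at least 6.6-fold higher number from compound 1 to compound 2 (0.82 log units; beyond the scatter), is therefore bounded by the limit of > 164000 nM in this assay, at which 1 of the 2 values shown sits, and only its lower size is known; compound 2 thus stands at the upper limit of the numbers shown, that is, at the less toxic end.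

Compound 3 `C#CCNC(=O)COc1cc(C)nc2ccc(OC)cc12` differs from compound 2 by ethynyl in place of methoxymethyl on a saturated chain carbon bound to an amide-type nitrogen. For the measured compounds named here, no measured step concerns this change, which lies outside the amide link altered from compound 1 to compound 2. In this assay a step from compound 2 to compound 3 of no more than an at least 1.0-fold lower number from compound 2 to compound 3 (0.03 log units; that floor lies within the scatter) is expected, with direction uncertain. Compound 3 is estimated at 150000 nM, with a range from 50000 nM to 500000 nM, and a limit rather than a number is considered likely.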

Compound 3, half-maximal cytotoxic concentration: > 176000 nM
Compound 3 ended at the assay's limit (the forecaster's own chance of this, stated with the estimate: 65%); middle value at least 1.1-fold (0.06 log units) from the limit.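

Propargyl in place of 3-methoxyphenyl on the amide-type nitrogen gives an at least 7.1-fold higher number from compound 1 to compound 3 (0.85 log units; beyond the scatter) in this assay, so a second chain without a ring, after 2-methoxyethyl, ends on the less toxic side of compound 1. Compound 3 stands at a limit of the test: the limit of > 176000 nM in this assay, at which 1 of the 3 values shown sits.

With compound 2 also at a limit, the step between these two cannot be read, and ethynyl in place of methoxymethyl on the saturated chain carbon has no readable size or direction.

How far beyond their limits compound 2 and compound 3 lie remains unknown, and 3-methoxyphenyl in compound 1 is the only ring-bearing group shown on this nitrogen. Open, as far as these compounds go, is how an unsubstituted phenyl ring, a longer chain, or a chain ending in an amine or a carboxylic acid would read in this assay.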